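The source may report more compounds than this note shows. Statements on the series, on what has been measured and on what is new or still open speak of the compounds shown alone.

Values measured so far in a physicochemical assay for solubility; on this read-out lower numbers stand for lower solubility and higher numbers for higher solubility
Compound 1 `O=C(c1cccnc1)N1CCC(NS(=O)(=O)c2cc(S(=O)(=O)c3ccccc3)ccc2C(F)(F)F)CC1` gives 50000 nM
Compound 2 `O=S(=O)(NC1CCN(S(=O)(=O)c2ccccc2)CC1)c1cc(S(=O)(=O)c2ccccc2)ccc1C(F)(F)F` gives 25000 nM
Compound 3 `O=S(=O)(NC1CCN(S(=O)(=O)c2cccc(-c3nnn[nH]3)c2)CC1)c1cc(S(=O)(=O)c2ccccc2)ccc1C(F)(F)F` gives 100000 nM

Compound 1 sits within the usual scatter of both other compounds, although those two lie beyond the scatter of each other. The next compound to be measured is compound 4 `O=C(O)c1ccc(N2CCC(NS(=O)(=O)c3cc(S(=O)(=O)c4ccccc4)ccc3C(F)(F)F)CC2)cc1` which keeps the core of compound 1 and differs in one place. The change is 4-carboxyphenyl in place of (pyridin-3-yl)carbonyl on an amine nitrogen in a ring and in words it puts 4-carboxyphenyl in place of (pyridin-3-yl)carbonyl on an amine nitrogen in a ring.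

Among the measured compounds shown here, two measured steps bear on this. For the measured compounds named here, the first replaces the group on that same nitrogen and amounts to a 2.0-fold lower number from compound 1 to compound 2 (0.30 log units; within the scatter) so that single swap gave no clear movement. The second puts 1H-tetrazol-5-yl in place of hydrogen on an aromatic carbon and amounts to a 4.0-fold higher number from compound 2 to compound 3 (0.60 log units; beyond the scatter) which is modest. Going by the values given here, neither is a direct match, since no measured compound carries 4-carboxyphenyl. Taking these two steps as the only guides, a small upward step is expected in this assay and it may stay close to the scatter. The estimated step is a 1.8-fold higher number from compound 1 to compound 4 (0.26 log units; within the scatter) on this reading. For compound 4 the expected value is 90000 nM with an estimated range from 35000 nM to 200000 nM around it.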

Compound 4, solubility: 25000 nM
Compound 4: the middle estimate sits 3.6-fold (0.56 log units) above what was measured; measured number outside the range, below it.
By their numbers in this assay, from the lowest: compounds 2, 4, 1 and 3 (each within the scatter of the next, the first and the last beyond it).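

In this assay, 4-carboxyphenyl on this amine nitrogen in a ring gives a 2.0-fold lower number from compound 1 to compound 4 (0.30 log units; within the scatter), and the same group in place of phenylsulfonyl gives no change at the digits printed from compound 2 to compound 4 (within the scatter). This position now carries three quite different groups, (pyridin-3-yl)carbonyl, phenylsulfonyl and 4-carboxyphenyl, and compounds 1, 2 and 4 all lie within the scatter of one another, so exchanging one of these whole groups for another has not produced a clear movement on this read-out. Among the one-place changes shown, the only step beyond the scatter remains the addition of 1H-tetrazol-5-yl to an aromatic carbon, a 4.0-fold higher number from compound 2 to compound 3 (0.60 log units; beyond the scatter), and the new group on the nitrogen does not repeat that movement.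

Nothing among the data shown explains why these three groups read so alike. Going by these compounds, it remains open whether a different kind of group on this nitrogen, such as an amine or a plain alkyl chain, or a carboxylic acid held on a longer chain, would move the number beyond the scatter.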